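A few compounds are considered here, and "the series" means these few. Any claim that something is new, unique, unknown or untested is made for them only; others in the source may bear on it.

Among the measured compounds shown here, compound 3, `COC(=O)[C@H](CC(C)C)NC(=O)c1cnc2ccccc2c1Cl`, is one of three compounds measured in an ADME assay on CCRF-CEM cells (Homo sapiens) for cytotoxicity (a lower number here means that less compound is tolerated, a higher number that more compound is tolerated), where compound 3 gives 49.1 uM. Compound 2, `COC(=O)[C@H](C)NC(=O)c1cnc2ccccc2c1Cl`, gives 81.3 uM in this assay. Compound 1, `CC(C)C[C@@H](CO)NC(=O)c1cnc2ccccc2c1Cl`, gives only a limit in this assay, > 100 uM; that value is a limit, not a number, as noted in the limit of > 100 uM in this assay, at which 1 of the 3 values shown sits. Among the numbers shown, compound 3 has the lowest, with compound 2 nearest: the step of a 1.7-fold lower number from compound 2 to compound 3 (0.22 log units; within the scatter) lies within the scatter. The step of an at least 2.0-fold lower number from compound 1 to compound 3 (0.30 log units; that floor lies within the scatter) has a floor that also lies within the scatter.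

Compound 4, `COC(=O)[C@@H](NC(=O)c1cnc2ccccc2c1Cl)[C@@H](C)O`, differs from compound 3 by 1-hydroxyethyl in place of isobutyl on a saturated chain carbon bound to an amide-type nitrogen and a carbonyl carbon. For the measured compounds named here, two measured steps bear on this change: the loss of the isopropyl branch runs opposite to the step from compound 2 to compound 3, and the entry of a hydroxyl group runs opposite to the step from compound 1 to compound 3. Both point towards a higher number, each by a small amount, so a modest rise in this assay is expected for compound 4, a 1.7-fold higher number from compound 3 to compound 4 (0.24 log units; within the scatter), and it may reach the limit. Compound 4 is therefore estimated at 85 uM, with a range from 45 uM to 150 uM.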

Compound 4, half-maximal toxic concentration: > 100 uM
Compound 4: no number, only a limit; the forecaster's own chance of this, stated with the estimate: 40%; middle value at least 1.1-fold (0.07 log units) from the limit.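

In this assay compound 4 gives > 100 uM, which is a limit and not a number. Putting 1-hydroxyethyl at this position gives an at least 2.0-fold higher number from compound 3 to compound 4 (0.30 log units; that floor lies within the scatter), and the same group in place of methyl gives an at least 1.2-fold higher number from compound 2 to compound 4 (0.08 log units; that floor lies within the scatter), so both steps are known only as floors. Compound 4 keeps the methoxycarbonyl of compound 2 and compound 3, yet it stands with compound 1, so among these compounds a methoxycarbonyl does not by itself go with a measurable number: the limit of > 100 uM in this assay, at which 2 of the 4 values shown sit.

As far as these compounds go, how far compound 1 and compound 4 lie beyond the limit stays unknown, so they cannot be ordered against each other. The compounds shown also do not separate the entry of the hydroxyl from the loss of isobutyl, and they leave open how an amine or a carboxylic acid at this position would read in this assay.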